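The source may report more compounds than this note shows. Statements on the series, on what has been measured and on what is new or still open speak of the compounds shown alone.

Three compounds were tested in a functional assay on the whole organism (strain Swiss) with Mus musculus as the target, in the maximal electroshock model, with a stated time of 1 h, at a dose of 300 mg/kg by the intraperitoneal route; a lower number here means a weaker effect, a higher number a stronger effect of the compound at the dose given. Compound 1, `CCC(C(=O)N1CCN(c2cccc(F)c2)CC1)N1C(=O)CCC1=O`, gave 75%. Compound 2, `CCC(C(=O)N1CCN(c2ccc(F)cc2)CC1)N1C(=O)CCC1=O`, gave 25%, and compound 3, `CC(C(=O)N1CCN(c2ccc(F)cc2)CC1)N1C(=O)CCC1=O`, gave 25%. Two single changes link them. Between compound 2 and compound 1 the change is 3-fluorophenyl in place of 4-fluorophenyl on an amine nitrogen in a ring, and it brought a number 50 percentage points higher from compound 2 to compound 1 (beyond the scatter). Between compound 2 and compound 3 the change is hydrogen in place of methyl on a saturated chain carbon, two bonds along the chain from an amide-type nitrogen in a ring and a carbonyl carbon, and the result was no change at the digits printed from compound 2 to compound 3 (within the scatter); compound 3 and compound 2 thus stand together at the lowest of the three numbers.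

A fourth compound, compound 4, `CC(C(=O)N1CCN(c2cccc(F)c2)CC1)N1C(=O)CCC1=O`, has not yet been measured in this assay. It differs from compound 3 by 3-fluorophenyl in place of 4-fluorophenyl on an amine nitrogen in a ring. Among the measured compounds shown here, this is the same change as the one that separates compound 2 from compound 1, made at the same place, and the two cores on which it is made differ only by hydrogen in place of methyl on a saturated chain carbon, two bonds along the chain from an amide-type nitrogen in a ring and a carbonyl carbon. For the measured compounds named here, the earlier instance made a large step, and that step is the sole guide here, since compound 3 matches compound 2 at the digits reported. Compound 4 is therefore expected to show a number 45 percentage points higher from compound 3 to compound 4 (beyond the scatter) in this assay, because the matching step was a number 50 percentage points higher from compound 2 to compound 1 (beyond the scatter). On that basis compound 4 is estimated at 70%, with an expected range from 40% to 95%, the width reflecting that the expectation rests on a single earlier pair.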

Compound 4, a percentage reported as activity, at one dose (the size of the read-out at that dose, not a potency): 75%
The estimate for compound 4 lay 5 percentage points below the measured number; low and high end bracket the measured number.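

In this assay, 3-fluorophenyl in place of 4-fluorophenyl brought a number 50 percentage points higher from compound 3 to compound 4 (beyond the scatter), so the step seen on the core of compound 2 recurred on the core of compound 3: the same change on two cores in this assay, a number 50 percentage points higher (beyond the scatter) from compound 2 to compound 1 and a number 50 percentage points higher (beyond the scatter) from compound 3 to compound 4, 0 percentage points apart, within the scatter of two such steps

The other single change also held across the two aryl groups, with hydrogen in place of methyl on the saturated chain carbon bringing no change at the digits printed from compound 1 to compound 4 (within the scatter): the same change on two cores in this assay, no change at the digits printed (within the scatter) from compound 2 to compound 3 and no change at the digits printed (within the scatter) from compound 1 to compound 4, 0 percentage points apart, within the scatter of two such steps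

Together these four compounds show that the two changes behave independently within this small square, but the evidence rests on only two cores that differ by a single methyl, and each number is a read-out at one dose rather than a potency, so it does not show that the step would carry to a more distant core or why the 3-fluorophenyl compounds stand higher.

The compounds shown leave open whether the step keeps its size with a longer chain, such as propyl, on the saturated chain carbon, or with chlorine or a trifluoromethyl group in place of fluorine on the phenyl ring. They also leave open whether the gap between the two fluorophenyl groups would persist at a lower dose in this assay.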